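The source may report more compounds than this note shows. Statements on the series, on what has been measured and on what is new or still open speak of the compounds shown alone.

Measured compounds in a functional assay (trachea) for inhibition, with Cavia porcellus as the target; on this read-out lower numbers stand for stronger inhibition and higher numbers for weaker inhibition:
Compound 1, `Cc1ccc2c(c1)[C@@H](N1CCCC1=O)[C@H](O)C(C)(C)O2`, gives 13500 nM.
Compound 2, `CC1(C)Oc2ccncc2[C@@H](N2CCCC2=O)[C@@H]1O`, gives 8600 nM.
Compound 3, `CC1(C)Oc2cc(C#N)ccc2[C@@H](N2CCCCC2=O)[C@@H]1O`, is reported only as a limit of this assay, > 17000 nM.

Compound 3 thus has no number of its own in this assay; it sits at the limit of > 17000 nM in this assay, at which 1 of the 3 values shown sits, and nothing finer can be said about where it stands relative to compound 1 or compound 2. Among the measured compounds shown here, only two compounds carry numbers, both weak, and neither differs from compound 3 in a single place, so no measured step tells how far a change at the aromatic ring moves this read-out.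

Compound 4, `CCc1ccc2c(c1)OC(C)(C)[C@@H](O)[C@@H]2N1CCCCC1=O`, is not yet measured. It differs from compound 3 by ethyl in place of cyano on an aromatic carbon. With compound 3 known only as a limit, the step cannot be calibrated against any measured pair. The expectation for this assay is a step of no more than the usual scatter, in no clear direction, and the estimate for the step is therefore a step that the limit leaves unreadable from compound 3 to compound 4. Compound 4 is expected to give about 20000 nM, within roughly 6000 nM to 60000 nM, with a fair chance that this assay again returns only a limit.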

Compound 4, half-maximal inhibitory concentration: 2250 nM
Beside the measured number, compound 4's estimate is 8.9-fold (0.95 log units) above it; measured number below the stated range.
By their numbers in this assay, from the lowest: compound 4; then compounds 2 and 1 (each within the scatter of the next). At a limit, above all of these: compound 3.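

Ethyl in place of cyano on an aromatic carbon gives, in this assay, an at least 7.5-fold lower number from compound 3 to compound 4 (0.87 log units; beyond the scatter), the first single-place step in the series and one beyond the scatter. This aromatic carbon therefore affects the read-out, even though both groups have 2 heavy atoms and no ring; the leaving cyano counts 1 hydrogen-bond acceptor and the entering ethyl none. The true size of the step remains unknown, because compound 3 stands only at a limit: the limit of > 17000 nM in this assay, at which 1 of the 4 values shown sits.

On these data alone, whether the shift follows from the loss of cyano or from the presence of ethyl stays open; hydrogen, methoxy or a longer chain such as propyl on this carbon would separate the two readings. Also open, as far as these compounds go, is whether ethyl would have a similar effect on the core of compound 1.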